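A few compounds are considered here, and "the series" means these few. Any claim that something is new, unique, unknown or untested is made for them only; others in the source may bear on it.

Measured compounds:
compound 1 `Fc1ccc(-c2cn3ccnc3c(-c3ccc4ncn(C5CCCCC5)c4c3)n2)cc1` with 7.94%; compound 2 `c1cn2cc(-c3ccc4c(c3)ncn4C3CCCCC3)nc(-c3ccc4ncn(C5CCCCC5)c4c3)c2n1` with 38.7%.

Both were tested in a functional assay on U-251 cells (Homo sapiens) for inhibition, read by sulforhodamine B assay, with a stated time of 48 h, tested at 10 uM; a lower number here means less inhibition, a higher number more inhibition at the concentration tested (going by the name of the read-out). Compound 2 stands highest of the two numbers; its nearest neighbour is compound 1, which sits lower by a gap beyond the usual scatter. Among the measured compounds shown here, no pair of measured compounds differs in a single place, so no step size can be read from the data. Compound 3 `c1ccc(Cn2cnc3ccc(-c4nc(-c5ccc6c(c5)ncn6C5CCCCC5)cn5ccnc45)cc32)cc1` differs from compound 2 in one place: benzyl in place of cyclohexyl on an aromatic nitrogen. Without a comparable step, the change from compound 2 to compound 3 is expected to stay close to compound 2, as a number 3.7 percentage points lower from compound 2 to compound 3 (within the scatter). Compound 3 is therefore estimated at 35%, within the range 10% to 60%.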

Compound 3, a percentage reported as inhibition, at one concentration (the size of the read-out at that concentration, not a potency): -22.8%
The estimate for compound 3 lay 57.8 percentage points above the measured number; the whole stated range lies above it.
By their numbers in this assay, from the lowest: compound 3; then compound 1; then compound 2.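

In this assay, the group on this aromatic nitrogen moves the read-out well beyond the scatter: benzyl in place of cyclohexyl gives a number 61.5 percentage points lower from compound 2 to compound 3 (beyond the scatter). Compound 3 reads -22.8%, a number below zero, so this change takes the read-out past zero rather than only lowering it. Nothing measured here accounts for the step. The compounds shown leave open whether the step follows the aromatic ring or the extra carbon of benzyl, and how a cyclopentyl group or a longer chain carrying an amine would read on this nitrogen.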